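Trimming the Ketone Side Chain of Compound 2

The source may report more compounds than this note shows. Statements on the series, on what has been measured and on what is new or still open speak of the compounds shown alone.

Compound 2 `Cc1c(OCCCCOc2ccccc2C(=O)O)ccc(C(=O)CC2CCCC2)c1O` is one of three compounds tested in an assay on HEK293 cells for positive allosteric modulation of metabotropic glutamate receptor 3 (Rattus norvegicus), read by thallium flux, with a stated time of 2.5 min; a lower number here means a smaller maximal response, a higher number a larger maximal response. In this assay compound 2 reaches 32.9%, which places it second highest of the three. Compound 1 `Cc1c(OCCCCOc2ccccc2C(=O)O)ccc(C(=O)CC2CCCC2)c1C` gives 28%. Compound 3 `Cc1c(OCCCCOc2cccc(C(=O)O)c2)ccc(C(=O)CC2CCCC2)c1O` gives 92.9%. The step of a number 4.9 percentage points higher from compound 1 to compound 2 (within the scatter) puts hydroxy in place of methyl on an aromatic carbon. The step of a number 60 percentage points higher from compound 2 to compound 3 (beyond the scatter) puts 3-carboxyphenyl in place of 2-carboxyphenyl on an oxygen on a saturated carbon.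

Compound 4 `Cc1c(OCCCCOc2ccccc2C(=O)O)ccc(C(=O)CC(C)C)c1O` has not yet been measured. It differs from compound 2 in one place: isopropyl in place of cyclopentyl on a saturated chain carbon bound to a carbonyl carbon Read one bond further out, (cyclopentylmethyl)carbonyl becomes isobutylcarbonyl. Neither measured step touches this part of the molecule: one altered a group on an aromatic carbon, the other the carboxyphenyl on the oxygen on a saturated carbon. There is no direct guide, and a change that removes one five-membered non-aromatic ring of carbon only while keeping everything else could move the maximal response either way. With nothing pointing in a direction, the expectation is no step beyond the usual scatter, a number 0.1 percentage points higher from compound 2 to compound 4 (within the scatter). Compound 4 is thus estimated at 33%, with a range from 15% to 55%.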

Compound 4, largest response reached (reported as percent of maximum), in percent of the reference or control that the assay uses: 28.1%
Compound 4: middle estimate off by 4.9 percentage points, on the high side; low and high end bracket the measured number.
By their numbers in this assay, from the lowest: compounds 1, 4 and 2 (each within the scatter of the next); then compound 3.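

In this assay, going by these compounds alone, the first change at this end of the molecule, isopropyl in place of cyclopentyl on a saturated chain carbon bound to a carbonyl carbon, gives a number 4.8 percentage points lower from compound 2 to compound 4 (within the scatter). Going from 5 heavy atoms to 3 and losing the one five-membered ring therefore leaves the maximal response indistinguishable, so with the 2-carboxyphenyl group in place, the cyclopentyl ring is not needed to hold the response at this level; the much larger shift among these compounds remains a number 60 percentage points higher from compound 2 to compound 3 (beyond the scatter), at the other end of the molecule. No measurement here explains why this swap leaves the number within the scatter.

As far as these compounds go, the result comes from the low-response series carrying the 2-carboxyphenyl group, so it remains open whether the same swap would also leave the response unchanged with the 3-carboxyphenyl group of compound 3, which stands at 92.9%. Also open, from the compounds shown here alone, is how this position would respond to groups unlike the two small carbon-only ones seen so far, such as a phenyl ring, an amine or a longer chain.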